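The source may hold more compounds than are shown below. What is called first, only, known or untested is meant among the compounds shown, and "the series" means these compounds.

Measured so far:
compound 1, `CCCCNc1nc(N)nc(C)c1C#CCN1CCCCC1`: 3790 nM
compound 2, `CCCCNc1nc(N)nc(C)c1CCCn1cncn1`: 1050 nM

Both compounds were tested in an assay on HEK293 cells for agonist activity at Toll-like receptor 8 (Homo sapiens), read by spectrophotometry; a higher number here means that more compound is needed for the effect, a lower number that less compound is needed. Of the two numbers, compound 1 carries the higher one: in this assay compound 1 gives 3790 nM, whereas compound 2 gives 1050 nM, and the gap between these two values lies beyond the usual scatter of repeat measurements.

Compound 3, `CCCCNc1nc(N)nc(C)c1C#C[Si](C)(C)C`, has not yet been measured. It keeps the core of compound 1 together with its triple bond and differs from compound 1 in a single place: a group of 4 heavy atoms (3 carbon, 1 silicon; no ring) in place of a group of 7 heavy atoms (6 carbon, 1 nitrogen; one six-membered non-aromatic ring with 1 hetero atom), on a triple-bonded carbon. For the measured compounds named here, no pair of measured compounds shows a change of this kind, so there is no measured step that points the way. The step expected from compound 1 to compound 3 is a 1.7-fold higher number from compound 1 to compound 3 (0.23 log units; within the scatter), a move toward a higher number, though the uncertainty runs in both directions. The value expected for compound 3 in this assay is 6500 nM, with a range from 1500 nM to 28000 nM.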

Compound 3, half-maximal effective concentration: 9240 nM
Beside the measured number, compound 3's estimate is 1.4-fold (0.15 log units) below it; the measured number falls inside the stated range.
By their numbers in this assay, from the lowest: compound 2; then compound 1; then compound 3.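

In this assay, the group on the triple-bonded carbon proves not to be a neutral passenger: replacing (piperidin-1-yl)methyl with the group of carbon and silicon atoms gives a 2.4-fold higher number from compound 1 to compound 3 (0.39 log units; beyond the scatter) and so calls for more compound to reach the effect. This is the first pair shown that differs in one place only, so it gives the first direct reading of a change at this position, and that reading favours the piperidine-bearing group over the silicon-bearing one. No measurement at hand bears on the reason for this step.

The change alters several things at once, removing the ring and the nitrogen with its hydrogen-bond acceptor and reducing the number of heavy atoms, so the compounds shown leave open which of these features matters for the number. An open-chain amine such as dimethylaminomethyl would keep the nitrogen without the ring, and a plain cyclohexylmethyl group would keep the ring without the nitrogen, so placing each on the same triple-bonded carbon would help pull these features apart.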